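Swapping a Phenyl for a Heptyl on a Carbonyl Carbon

The source may report more compounds than this note shows. Statements on the series, on what has been measured and on what is new or still open speak of the compounds shown alone.

Measured so far in an assay on nucleic acid for inhibition of Nucleic Acid, read by fluorescence, tested at 100 uM; on this read-out lower numbers stand for less inhibition and higher numbers for more inhibition at the one concentration tested (going by the name of the read-out):
- compound 1, `CCCCN(CCCC)Cc1cn(CC(O)COC(=O)NCc2ccccc2)nn1`, gives 42%
- compound 2, `CCCCN(CCCC)Cc1cn(CC(O)COC(=O)c2ccccc2)nn1`, gives 12%

Going by the values given here, compound 2 stands lowest of the two numbers in this assay; its nearest neighbour is compound 1, and the one measured step, a number 30 percentage points lower from compound 1 to compound 2 (beyond the scatter), lies beyond the scatter. Compound 3, `CCCCCCCC(=O)OCC(O)Cn1cc(CN(CCCC)CCCC)nn1`, has not yet been measured. It differs from compound 2 by heptyl in place of phenyl on a carbonyl carbon. Among the compounds with values here, no measured step touches this change: the only step known alters the other side of the same carbonyl carbon, benzylamino to phenyl, and says nothing about phenyl against heptyl. With nothing to point either way, a step in this assay of no clear direction, and not beyond the scatter, is expected, so that a number 6 percentage points higher from compound 2 to compound 3 (within the scatter) is the estimated change. Compound 3 is therefore expected to give about 18%, within a wide range from 0% to 45%.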

Compound 3, a percentage reported as inhibition, at one concentration (the size of the read-out at that concentration, not a potency): 71%
Beside the measured number, compound 3's estimate is 53 percentage points below it, and the stated range ends below it.
By their numbers in this assay, from the lowest: compound 2; then compound 1; then compound 3.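

In this assay the choice of group on the carbonyl carbon weighs heavily: heptyl in place of phenyl gives a number 59 percentage points higher from compound 2 to compound 3 (beyond the scatter) even though both groups are carbon only, with no hydrogen-bond donors or acceptors and no net charge. Heptyl in place of benzylamino gives a number 29 percentage points higher from compound 1 to compound 3 (beyond the scatter) as well, so among these three compounds the group without a ring gives the highest number, and the two groups with a ring both stand lower. Nothing shown here explains this difference between the chain and the ring-bearing groups.

Going by these compounds, it remains open how the number would respond to a shorter chain such as butyl or a longer one such as decyl. A cyclohexyl group would test whether a ring of carbon that is not aromatic behaves more like phenyl or more like heptyl.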